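Swapping Fluorines for Chlorines on the Side Ring

This account rests on a few compounds, and the source may have more. Where it says the series, first, only, none or still open, it means among the compounds named here.

Compound 1 `COc1cc(C(=O)N/N=C/c2ccc(F)c(F)c2)cc(OC)c1OC`: 51.9%
Compound 2 `COc1cc(C2=NN(C(C)=O)C(c3ccc(F)c(F)c3)O2)cc(OC)c1OC`: 21.6%
Compound 3 `COc1cc(C(=O)N/N=C/c2cccc(C(F)(F)F)c2)cc(OC)c1OC`: 33.8%

These three compounds were tested in a functional assay on BGC-823 cells (Homo sapiens) for antiproliferative activity, read by MTT assay, tested at 5 uM; a higher number here means a stronger effect of the compound at the concentration tested, a lower number a weaker effect. Compound 1 gives 51.9%, the highest of the three numbers. Compound 3 gives 33.8%, a number lower by more than the usual scatter, and compound 2 gives 21.6%, further below still. Compound 1 is therefore the strongest of the measured set under these conditions.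

The unmeasured compound 4 `COc1cc(C(=O)N/N=C/c2ccc(Cl)c(Cl)c2)cc(OC)c1OC` keeps the core of compound 1 and changes only the ring sitting on a carbon with a double bond to nitrogen: 3,4-dichlorophenyl in place of 3,4-difluorophenyl on a carbon with a double bond to nitrogen. For the measured compounds named here, no measured pair in this set differs in just one place, so there is no directly comparable step to lean on. The change keeps the count of heavy atoms and the pattern of two halogens on the ring. The step is expected to be small, a number 2.1 percentage points higher from compound 1 to compound 4 (within the scatter), not beyond the scatter in either direction. Compound 4 is thus estimated at 54%, with a range from 38% to 70%.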

Compound 4, a percentage reported as inhibition, at one concentration (the size of the read-out at that concentration, not a potency): 32.7%
The estimate for compound 4 lay 21.3 percentage points above the measured number, outside the stated range (below it).
By their numbers in this assay, from the lowest: compound 2; then compounds 4 and 3 (each within the scatter of the next); then compound 1.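

In this assay, for the compounds shown here, this is the first comparison in the set that changes only one place, and it shows that the choice of halogen on this ring matters: 3,4-dichlorophenyl in place of 3,4-difluorophenyl, on a carbon with a double bond to nitrogen, gives a number 19.2 percentage points lower from compound 1 to compound 4 (beyond the scatter). The count of heavy atoms and the two-halogen pattern stay the same, yet the read-out still moves by more than the usual scatter. No measurement available here accounts for this drop.

This single step does not show how the read-out responds to other groups on this ring, such as a hydroxyl, a nitrile or an amine. On these data alone, whether the same swap of halogens would act alike on the core of compound 2 also stays open.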